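This account rests on a few compounds, and the source may have more. Where it says the series, first, only, none or still open, it means among the compounds named here.

Measured compounds:
- compound 1, `Cn1cccc1-c1nc2cc(NC(=O)CCCl)ccc2[nH]1` — in a functional assay on HepG2 cells (Homo sapiens) for cytotoxicity, read by MTT assay, with a stated time of 72 h (a higher number here means a weaker inhibitor, a lower number a stronger inhibitor), compound 1 gives > 50000 nM, which is a limit of the assay rather than a number
- compound 2, `Cc1ccc(-c2nc3cc(NC(=O)CCCl)ccc3[nH]2)cc1` — in this assay compound 2 gives > 50000 nM, again a limit and not a number

Among the compounds with values here, compound 2 thus stands at the limit with no measured number of its own; the only other value shown is likewise a limit. Within the data shown here, the single step between measured compounds, a step that the two limits leave unreadable from compound 1 to compound 2, cannot be sized since both ends sit at the limit. The evidence available is the limit of > 50000 nM in this assay, at which 2 of the 2 values shown sit.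

Compound 3, `Cc1ccc(-c2nc3cc(NC(=O)CN4CCCC4)ccc3[nH]2)cc1`, differs from compound 2 by pyrrolidin-1-yl in place of chloromethyl on a saturated chain carbon bound to a carbonyl carbon. Among the measured compounds shown here, no measured step touches this part of the molecule, so nothing shows how it moves the read-out in either direction. With both values at the limit, the expectation for compound 3 is set by that limit alone. The step that the limit leaves unreadable from compound 2 to compound 3 is therefore estimated as no change beyond the scatter. Compound 3 is expected to give about 60000 nM in this assay, within 20000 nM to 200000 nM, most likely reported again as a limit.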

Compound 3, half-maximal inhibitory concentration: > 50000 nM
Compound 3: a limit, no number (the forecaster's own chance of this, stated with the estimate: 80%); the middle value is on the limit's open side.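

In this assay compound 3 gives > 50000 nM, a limit and not a number, so no size can be read for the change from compound 2 to compound 3. The compounds shown leave open which change to the series, if any, would yield a measured number rather than a limit: the limit of > 50000 nM in this assay, at which 3 of the 3 values shown sit.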